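Swapping Isopropyl for Benzyl on the Ether Oxygen

The compounds below may be only part of what the source reports. "The series", "measured", "known", "first", "only" and "open" are said of these compounds alone.

Compound 1, `CC(C)Oc1cncc(C2=CC3CNCC(C2)C3)c1`, gives 4.8 nM in an in vitro assay on SH-SY5Y cells for displacement of a labelled ligand from Neuronal acetylcholine receptor; alpha3/beta4 (Homo sapiens); a higher number here means a weaker inhibitor, a lower number a stronger inhibitor.
Compound 2, `C1=C(c2cccnc2)CC2CNCC1C2`, gives 12 nM in this assay.
Compound 3, `CC(C)Oc1cncc(C2=CC3CC(C2)CN(C)C3)c1`, gives 1730 nM in this assay.

Compound 1 stands lowest of the three numbers, and so is the strongest inhibitor among them; both steps from it to the others are beyond the scatter. Compound 4, `C1=C(c2cncc(OCc3ccccc3)c2)CC2CNCC1C2`, has not yet been measured. It differs from compound 1 in one place: benzyl in place of isopropyl on an oxygen on an aromatic ring.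

Going by the values given here, only one measured step touches this place. Removing the group on that oxygen altogether, a 2.5-fold higher number from compound 1 to compound 2 (0.40 log units; beyond the scatter), is a modest loss, so the group matters, though not greatly. The other step, a 360-fold higher number from compound 1 to compound 3 (2.56 log units; beyond the scatter), concerns the amine nitrogen in the ring and says nothing about the ether. Among the compounds with values here, no measured pair compares one group on the oxygen against another, so the effect of a larger group there is unknown here. Since the whole group is worth only a modest step, exchanging it for another is expected to move the number little, within or close to the scatter, in either direction.

Compound 4 is therefore expected to give about 6 nM, with a range from 2 nM to 20 nM. That estimate means a step of a 1.3-fold higher number from compound 1 to compound 4 (0.10 log units; within the scatter), expected to stay near the scatter.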

Compound 4, inhibition constant: 44 nM
Compound 4: the middle estimate sits 7.3-fold (0.87 log units) below what was measured, outside the stated range (above it).
By their numbers in this assay, from the lowest: compound 1; then compound 2; then compound 4; then compound 3.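

In this assay, the group on this oxygen matters by its identity and not merely by its presence: benzyl in place of isopropyl gives a larger step (a 9.2-fold higher number from compound 1 to compound 4 (0.96 log units; beyond the scatter)) than hydrogen in place of the whole isopropoxy group (a 2.5-fold higher number from compound 1 to compound 2 (0.40 log units; beyond the scatter)). Compound 2, which has no ether at all, reads (12 nM) and compound 4 reads (44 nM), so on these numbers isopropyl does better than hydrogen on that aromatic carbon, whereas the benzyl ether does worse, and the position cannot be treated as one where any group will do. Nothing available explains why benzyl fares worse than isopropyl at this position.

With only two groups on the oxygen, the compounds shown cannot separate the effect of the aromatic ring in benzyl from that of the larger group as a whole, and cyclohexylmethyl, which has a ring of carbon that is not aromatic, would be a direct test of that. Going by these compounds, it also remains open how smaller groups such as methyl or ethyl, or a longer chain such as butyl, would compare with isopropyl on the same oxygen.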